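The compounds below may be only part of what the source reports. "The series", "measured", "known", "first", "only" and "open" are said of these compounds alone.

Three measured compounds share one core. Compound 1 `CCNc1ccc(NC(=O)c2cc(Cl)ccc2O)c(Cl)c1` gives 30200 nM in an ADME assay on A549 cells (Homo sapiens) for cytotoxicity, read by resazurin assay, with a stated time of 48 h; a higher number here means that more compound is tolerated, a lower number that less compound is tolerated. Compound 2 `CCCN(CCC)c1ccc(NC(=O)c2cc(Cl)ccc2O)c(Cl)c1` gives 10700 nM in this assay, and the step of a 2.8-fold lower number from compound 1 to compound 2 (0.45 log units; beyond the scatter) is the only one here that lies beyond the scatter. Compound 3 `O=C(Nc1ccc(NCc2ccccc2)cc1Cl)c1cc(Cl)ccc1O` gives 19700 nM in this assay; it stands second highest of the three numbers, with compound 1 nearest and compound 2 furthest, and both a 1.5-fold lower number from compound 1 to compound 3 (0.19 log units; within the scatter) and a 1.8-fold higher number from compound 2 to compound 3 (0.27 log units; within the scatter) lie within the scatter.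

Compound 4 `O=C(Nc1ccc(NCc2cccc(Br)n2)cc1Cl)c1cc(Cl)ccc1O` differs from compound 3 in one place: 6-bromopyridin-2-yl in place of phenyl on a saturated chain carbon bound to a nitrogen on an aromatic ring. Going by the values given here, the only measured step at the same place is a 1.5-fold lower number from compound 1 to compound 3 (0.19 log units; within the scatter), which stayed within the scatter; no measured step exchanges one aromatic ring for another at this place, so the data give no guide to such a swap. Compound 4 is therefore expected to show no step beyond the scatter, a 1.0-fold higher number from compound 3 to compound 4 (0.01 log units; within the scatter). The estimate for compound 4 in this assay is 20000 nM, with a range from 8000 nM to 50000 nM.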

Compound 4, half-maximal cytotoxic concentration: 92300 nM
For compound 4 the middle estimate is 4.6-fold (0.66 log units) below the measured one; measured number outside the range, above it.
By their numbers in this assay, from the lowest: compounds 2, 3 and 1 (each within the scatter of the next, the first and the last beyond it); then compound 4.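

Going by these compounds alone, at this position, on a saturated chain carbon bound to a nitrogen on an aromatic ring, the one earlier exchange had stayed within the scatter, whereas 6-bromopyridin-2-yl in place of phenyl gives a 4.7-fold higher number from compound 3 to compound 4 (0.67 log units; beyond the scatter) in this assay, so the number here does respond to the group placed at this position. The change also holds against the two other side groups, with a 3.1-fold higher number from compound 1 to compound 4 (0.49 log units; beyond the scatter) and an 8.6-fold higher number from compound 2 to compound 4 (0.94 log units; beyond the scatter), and this gives the highest number of the four, beyond the scatter of each of the others. Nothing shown accounts for this rise.

The compounds shown leave open whether the ring nitrogen or the bromine goes with the higher number, as neither plain pyridin-2-yl nor bromophenyl stands among them. On these data alone, whether chlorine or methyl could replace the bromine also remains open.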